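Removal of the methyl on the fused core

This account rests on a few compounds, and the source may have more. Where it says the series, first, only, none or still open, it means among the compounds named here.

Compound 2 `Cc1cccc2cc(-c3cccc(Br)c3)oc12` gives 3980 nM in an assay on cells for inhibition of Amine oxidase [flavin-containing] B (Homo sapiens), read by fluorescence and Amplex Red, with a stated time of 15 min (a lower number here means a stronger inhibitor, a higher number a weaker inhibitor), the highest of the two numbers available. Among the compounds with values here, the nearest is compound 1 `Cc1ccc2oc(-c3cccc(Br)c3)cc2c1`, which in this assay gives 250 nM; the gap between the two is beyond the usual scatter, and no single-site step links them, so only the two values themselves can be compared. Compound 3 `Brc1cccc(-c2cc3ccccc3o2)c1` differs from compound 2 by hydrogen in place of methyl on an aromatic carbon of the fused six-membered ring, ortho to a fused ring. Because compound 2 sits at 3980 nM while compound 1 with its methyl elsewhere on the core reaches 250 nM, the step from compound 2 to compound 3 is expected to bring a lower number, of a size beyond the scatter, a 13-fold lower number from compound 2 to compound 3 (1.12 log units; beyond the scatter). Compound 3 is estimated in this assay at 300 nM, with a range from 60 nM to 1500 nM.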

Compound 3, half-maximal inhibitory concentration: 1170 nM
Beside the measured number, compound 3's estimate is 3.9-fold (0.59 log units) below it, and the stated range covers the measured number.
By their numbers in this assay, from the lowest: compound 1; then compound 3; then compound 2.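

In this assay hydrogen in place of methyl on an aromatic carbon, ortho to a fused ring, brings a 3.4-fold lower number from compound 2 to compound 3 (0.53 log units; beyond the scatter) and shows that methyl at this position costs potency relative to hydrogen. The same replacement at the other methyl position gives a 4.7-fold higher number from compound 1 to compound 3 (0.67 log units; beyond the scatter) and so runs the opposite way, which makes the outcome of this change depend on where the methyl stands on the six-membered aromatic ring. No measurement at hand accounts for either direction.

The compounds shown leave open whether a longer chain such as ethyl, or a methoxy group, would follow the methyl at each of the two positions. Also open, from the compounds shown here alone, is whether a fluorine or chlorine atom at these positions would give numbers closer to those with methyl or with hydrogen.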